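A few compounds are considered here, and "the series" means these few. Any claim that something is new, unique, unknown or untested is made for them only; others in the source may bear on it.

In an ADME assay on RAW264.7 cells (Mus musculus) for cytotoxicity, read by MTT assay, with a stated time of 24 h, tested at 1.25 ug/mL (a lower number here means a stronger effect, a higher number a weaker effect of the compound at the concentration tested), compound 1, `COc1cc(/C=C/C(=O)c2cccc(O)c2)ccc1O`, gives 96.9%. Compound 2, `COc1ccc(/C=C/C(=O)c2ccc(OC)c(OC)c2)cc1OC`, gives 94% in this assay. Compound 3, `COc1ccc(/C=C/C(=O)c2cccc(O)c2)cc1OC`, gives 101% in this assay.

All three numbers lie close together, and none of the gaps between them reaches beyond the usual scatter of this read-out. Among the compounds with values here, the single counted change among the measured compounds is hydrogen in place of methyl on an oxygen on an aromatic ring, which gave a number 4.1 percentage points lower from compound 3 to compound 1 (within the scatter). How the core of compound 2 differs from the core of compound 3 is not broken down here.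

Compound 4, `COc1ccc(/C=C/C(=O)c2ccc(OC)c(OC)c2)cc1O`, has not yet been measured. It differs from compound 2 by hydrogen in place of methyl on an oxygen on an aromatic ring, the same change as that from compound 3 to compound 1. On that earlier step, which stayed within the scatter, the expected step in this assay is a number 3 percentage points lower from compound 2 to compound 4 (within the scatter). Compound 4 is therefore estimated at 91%, between 80% and 101%.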

Compound 4, a percentage reported as activity, at one concentration (the size of the read-out at that concentration, not a potency): 91.4%
Estimate against measurement, compound 4: 0.4 percentage points below, within the range that was stated.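

Swapping methyl for hydrogen on an oxygen on an aromatic ring gave a number 2.6 percentage points lower from compound 2 to compound 4 (within the scatter) in this assay. Set beside the earlier step, the change carries from one core to the other without a difference that can be told apart: the same change on two cores in this assay, a number 4.1 percentage points lower (within the scatter) from compound 3 to compound 1 and a number 2.6 percentage points lower (within the scatter) from compound 2 to compound 4, 1.5 percentage points apart, within the scatter of two such steps. Within the data shown here, this shows only that the change stayed within the scatter on these two cores at one concentration; it does not show that the change has a real effect of its own, or that it would behave alike on any other core.

The compounds shown carry only methoxy and hydroxy groups on their aromatic rings, so what an amine, a carboxylic acid or a longer chain would do there remains open. Whether any such group would move the number beyond the scatter in this assay is open too.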